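A few compounds are considered here, and "the series" means these few. Any claim that something is new, unique, unknown or untested is made for them only; others in the source may bear on it.

Working notes on the series. The common motif is a bis(aminomethyl)benzene core, and the compounds are compared in an assay on MDA-MB-231 cells for displacement of a labelled ligand from C-X-C chemokine receptor type 4 (Homo sapiens); a lower number here means that less compound is needed, a higher number that more compound is needed for the effect. Compound 1 `Fc1ccc(NCc2ccc(CNc3ccc(F)cn3)cc2)nc1` carries a 5-fluoropyridin-2-yl on both amine nitrogens; in this assay compound 1 gives 100 nM. Compound 2 `Clc1cccc(NCc2ccc(CNc3ncccn3)cc2)n1` pairs a pyrimidinyl amine with a 6-chloropyridin-2-yl, and in this assay compound 2 gives 1 nM. Compound 3 `Clc1ccc(NCc2ccc(CNc3ncccn3)cc2)nc1` keeps the pyrimidinyl amine but carries the 5-chloropyridin-2-yl; in this assay compound 3 gives 10 nM. Within these three numbers compound 3 stands second highest: its nearest neighbour is compound 1, and the step of a 10-fold higher number from compound 2 to compound 3 (1.00 log units; beyond the scatter) separates it from compound 2.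

Compound 4 `Fc1ccc(NCc2ccc(CNc3ncccn3)cc2)nc1` is the next member. It differs from compound 3 by fluoro in place of chloro on an aromatic carbon. For the measured compounds named here, no measured step swaps a halogen at the same place: the one step that is measured moves the chloro to another ring position, and compounds 1 and 3 differ in two places at once, so their numbers only bracket the question. The change is a single heavy atom, so for compound 4 the step of a 1.5-fold higher number from compound 3 to compound 4 (0.18 log units; within the scatter) is expected to lie within the scatter, perhaps leaning toward a higher number. Compound 4 is therefore estimated at 15 nM, with a plausible range from 5 nM to 50 nM.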

Compound 4, effective concentration (reported as EC, without a stated level of effect): 1 nM
Estimate against measurement, compound 4: 15-fold (1.18 log units) above, outside the stated range (below it).
By their numbers in this assay, from the lowest: compounds 2 and 4 (each within the scatter of the next); then compound 3; then compound 1.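

In this assay, the exchange of 5-chloropyridin-2-yl for 5-fluoropyridin-2-yl, on an aromatic carbon two atoms from the ring nitrogen, gives a 10-fold lower number from compound 3 to compound 4 (1.00 log units; beyond the scatter), so swapping one halogen for another at this place is enough to move the number beyond the scatter. The 5-fluoropyridin-2-yl does not set the number by itself: with the pyrimidinyl amine as its partner there is no change at the digits printed from compound 2 to compound 4 (within the scatter), while the exchange of one 5-fluoropyridin-2-yl on an amine nitrogen for pyrimidin-2-yl gives a 100-fold lower number from compound 1 to compound 4 (2.00 log units; beyond the scatter), the largest step among these compounds. Nothing available explains why the fluoro and chloro compounds differ at this place.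

On these data alone, it remains open whether the number at this place follows a simple trend once a hydrogen, a methoxy or a nitrile stands in for the halogen. As far as these compounds go, it is also open whether the fluoro-for-chloro step carries over to the ring position of the chloro group in compound 2, or to a compound with pyrimidin-2-yl replaced by an aminopyridine.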